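The compounds below may be only part of what the source reports. "The series", "measured", "known", "first", "only" and "open" are said of these compounds alone.

The compounds here share one core and differ only in what sits on a nitrogen on an aromatic ring. Compound 1 `c1ccc(-c2nc3ccccn3c2NCC2CC2)nc1` carries a cyclopropylmethyl group there; in an ADME assay on THP-1 cells (Homo sapiens) for cytotoxicity (a higher number here means that more compound is tolerated, a lower number that less compound is tolerated), compound 1 gives 19400 nM. Compound 2 `c1ccc(-c2nc3ccccn3c2NC2CCOC2)nc1` carries an oxolan-3-yl group instead. In this assay compound 2 reaches only the limit of the assay, > 50000 nM, and no number. The step of an at least 2.5-fold higher number from compound 1 to compound 2 (0.41 log units; beyond the scatter) is therefore only a lower bound on how far the number moved. Compound 3 `CN(c1ccc(F)cc1)c1c(-c2ccccn2)nc2ccccn12` places a methyl and a 4-fluorophenyl on that nitrogen. In this assay compound 3 also stops at the limit > 50000 nM and gives no number. So compound 2 stands where most of the measured values sit, (the limit of > 50000 nM in this assay, at which 2 of the 3 values shown sit).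

Compound 4 `Fc1cccc(Nc2c(-c3ccccn3)nc3ccccn23)c1` is the next compound: 3-fluorophenyl in place of oxolan-3-yl on a nitrogen on an aromatic ring. For the measured compounds named here, only one measured step touches this position, an at least 2.5-fold higher number from compound 1 to compound 2 (0.41 log units; beyond the scatter), and it ended at the limit, so its full size is unknown. Compound 3, with an aromatic fluorophenyl on the same nitrogen, sits at the limit as well. Because compound 3 gives > 50000 nM, compound 4 is expected to stay near the limit too. The estimate for compound 4 in this assay is 50000 nM, from 20000 nM to 100000 nM, and the expected step of a number no higher from compound 2 to compound 4 (the limit leaves the size open) is none beyond the scatter.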

Compound 4, half-maximal cytotoxic concentration: > 50000 nM
Compound 4: only a limit was reported (the forecaster's own chance of this, stated with the estimate: 65%); the middle value sits exactly at the limit.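

Replacing cyclopropylmethyl with 3-fluorophenyl on this nitrogen gives an at least 2.5-fold higher number from compound 1 to compound 4 (0.41 log units; beyond the scatter) in this assay, so a second replacement also ends higher, this time with a six-membered aromatic ring of carbon only rather than a five-membered non-aromatic ring with a hetero atom. Compound 4 gives > 50000 nM, which is a limit of the assay and not a number, and the step from the oxolan-3-yl group to the 3-fluorophenyl group cannot be read, as both ends of it are limits. Compound 1 is now the only compound here with a true number, while the others share one limit: the limit of > 50000 nM in this assay, at which 3 of the 4 values shown sit.

On these data alone, how far compound 2, compound 3 and compound 4 lie past that limit stays open, so these groups cannot be put in any order among themselves. Also open, as far as these compounds go, is whether a longer chain, a chain ending in an amine or a carboxylic acid on this nitrogen would give a number close to that of compound 1, or one lower still.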